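The compounds below may be only part of what the source reports. "The series", "measured", "known", "first", "only" and "open" are said of these compounds alone.

In an ADME assay on HEK-293T cells (Homo sapiens) for cytotoxicity, read by MTT assay, with a stated time of 48 h (on this read-out lower numbers stand for higher toxicity in this test and higher numbers for lower toxicity in this test), three compounds sharing one core have been tested so far. Compound 1 `Cn1cc(C2CC(c3ccccc3)=NN2C(=O)c2cccnc2)c2ccccc21` gives > 300000 nM as a limit of the assay, not a number. Compound 2 `COc1ccc(C(=O)N2N=C(c3ccccc3)CC2c2cn(C)c3ccccc23)cn1` gives > 300000 nM as a limit too. Compound 3 `Cn1cc(C2CC(c3ccccc3)=NN2C(=O)c2cccnc2)c2cc(Br)ccc21` gives > 300000 nM as a limit as well. Compound 3 therefore has no number of its own and stands with the others (the limit of > 300000 nM in this assay, at which 3 of the 3 values shown sit).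

Compound 4 `Cn1cc(C2CC(c3ccc(Br)cc3)=NN2C(=O)c2cccnc2)c2cc(Br)ccc21` differs from compound 3 by one change, phenyl to 4-bromophenyl (bromo in place of hydrogen on an aromatic carbon). This places bromo in place of hydrogen on an aromatic carbon.

Going by the values given here, two measured steps bear on this: bromo in place of hydrogen (a step that the two limits leave unreadable from compound 1 to compound 3) and methoxy in place of hydrogen (a step that the two limits leave unreadable from compound 1 to compound 2). Neither has a readable size, and neither brought a compound to a number. No step beyond the scatter is therefore expected in this assay and no direction can be named. The expected change is a number no higher from compound 3 to compound 4 (the limit leaves the size open) in this estimate. For compound 4 the estimate is 300000 nM with an expected range of 100000 nM to 500000 nM and another limit is the likeliest report.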

Compound 4, half-maximal cytotoxic concentration: > 300000 nM
Compound 4 ended at the assay's limit; the forecaster's own chance of this, stated with the estimate: 75%; the middle value lies on the limit itself.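

Going by these compounds alone, compound 4, like compound 3, gives a limit of the assay rather than a number, so no step between them can be read: (the limit of > 300000 nM in this assay, at which 4 of the 4 values shown sit). On these data alone, whether any change to the shared core would bring a measured number in this assay stays open.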